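The compounds below may be only part of what the source reports. "The series", "measured", "known", "first", "only" and "open" are said of these compounds alone.

Measured so far:
Compound 1 `CC(c1ccc(-c2ccccc2)c(F)c1)c1nnc2n1N=C(c1ccc(Cl)cc1)CS2` gives 8700 nM in a functional assay on MCF7 cells (Homo sapiens) for inhibition, read by sulforhodamine B assay, with a stated time of 72 h; on this read-out lower numbers stand for stronger inhibition and higher numbers for weaker inhibition.
Compound 2 `CC(c1ccc(-c2ccccc2)c(F)c1)c1nnc2n1N=C(c1ccc(F)cc1)CS2` gives 8100 nM in this assay.

Among the measured compounds shown here, on these two numbers compound 2 and compound 1 stand within the scatter of each other, the step of a 1.1-fold lower number from compound 1 to compound 2 (0.03 log units; within the scatter) being the only comparison available. Compound 3 `Cc1ccc(C2=Nn3c(nnc3C(C)c3ccc(-c4ccccc4)c(F)c3)SC2)cc1` differs from compound 2 by methyl in place of fluoro on an aromatic carbon. For the measured compounds named here, the one measured step that bears on this, a 1.1-fold lower number from compound 1 to compound 2 (0.03 log units; within the scatter), exchanges one substituent on that ring for another and moves the number by no more than the scatter; no measured step places a methyl there. The step of a 1.0-fold higher number from compound 2 to compound 3 (0.02 log units; within the scatter) is therefore expected to stay within the scatter. Compound 3 is estimated at 8500 nM, with a range from 4000 nM to 18000 nM.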

Compound 3, half-maximal inhibitory concentration: 5000 nM
Compound 3: middle estimate off by 1.7-fold (0.23 log units), on the high side; the measured number falls inside the stated range.
By their numbers in this assay, from the lowest: compounds 3, 2 and 1 (each within the scatter of the next).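

In this assay, methyl on the aromatic carbon para to a large group gives a 1.6-fold lower number from compound 2 to compound 3 (0.21 log units; within the scatter) and, set against chloro, a 1.7-fold lower number from compound 1 to compound 3 (0.24 log units; within the scatter). A carbon group at this position, and not only a halogen, thus keeps the number within the scatter of both halogen compounds. Nothing available offers a reason for these numbers.

From the compounds shown here alone, whether an amine, a carboxylic acid or a longer chain at this position would stay within the scatter remains open, as does whether any change here can move the number beyond it.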